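Working notes: fluoro on the fused ring system

A few compounds are considered here, and "the series" means these few. Any claim that something is new, unique, unknown or untested is made for them only; others in the source may bear on it.

Values in a functional assay on MCF7 cells (Homo sapiens) for inhibition (a higher number here means a weaker inhibitor, a lower number a stronger inhibitor), so far:
compound 1 `CCn1c(=O)/c(=C2\Sc3cc(F)ccc3N2C)s/c1=C\c1ccncc1Nc1ccccc1F` gives 230 nM
compound 2 `CCn1c(=O)/c(=C2\Sc3ccccc3N2C)s/c1=C\c1ccncc1Nc1ccccc1Cl` gives 750 nM
compound 3 `CCn1c(=O)/c(=C2\Sc3ccc(OC)cc3N2C)s/c1=C\c1ccncc1Nc1ccccc1Cl` gives 710 nM

Compound 2 has the highest number of the three. Compound 3 sits nearest, the step of a 1.1-fold lower number from compound 2 to compound 3 (0.02 log units; within the scatter) lying within the scatter. Going by the values given here, compound 1 sits furthest, its number being lower than that of compound 2 by more than the scatter; compound 1 and compound 2 differ in two places, so no single step is assigned to that pair.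

Compound 4 `CCn1c(=O)/c(=C2\Sc3cc(F)ccc3N2C)s/c1=C\c1ccncc1Nc1ccccc1Cl` is not yet measured. It is compound 2 with fluoro in place of hydrogen on an aromatic carbon. Among the compounds with values here, only one measured step concerns a change on the same fused ring system, a 1.1-fold lower number from compound 2 to compound 3 (0.02 log units; within the scatter), a methoxy entering, and it lay within the scatter. Compound 1 carries the same fluoro at this place together with fluoro in place of chloro on a different ring, and its number is lower than that of compound 2; how much of that belongs to each change is not known. Compound 4 is therefore expected to give a somewhat lower number, by a step of a 1.6-fold lower number from compound 2 to compound 4 (0.19 log units; within the scatter), with moderate confidence only. The estimate for compound 4 in this assay is 480 nM, ranging from 220 nM to 1000 nM.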

Compound 4, half-maximal inhibitory concentration: 1300 nM
Estimate against measurement, compound 4: 2.7-fold (0.43 log units) below; the measured number lies above the stated range.
By their numbers in this assay, from the lowest: compound 1; then compounds 3, 2 and 4 (each within the scatter of the next).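

In this assay, fluoro in place of hydrogen on this aromatic carbon gives a 1.7-fold higher number from compound 2 to compound 4 (0.24 log units; within the scatter), so this change alone does not separate compound 4 from compound 2. Chloro in place of fluoro on the other ring, with the fused-ring fluoro held constant, gives a 5.7-fold higher number from compound 1 to compound 4 (0.75 log units; beyond the scatter), which makes that halogen the only single change shown here to go beyond the scatter, though this step is marked as modest. No further data explain either step.

Still open, from the compounds shown here alone, is whether the halogen step keeps its size on the core of compound 2, without the fused-ring fluoro. Also open, going by these compounds, is how an amine, a carboxylic acid or a longer chain on this aromatic carbon would read in this assay.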